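The compounds below may be only part of what the source reports. "The series", "measured", "known", "first", "only" and "open" are said of these compounds alone.

In an ADME assay on HEK-293T cells (Homo sapiens) for cytotoxicity, read by MTT assay, with a stated time of 48 h (on this read-out higher numbers stand for lower toxicity in this test and lower numbers for higher toxicity in this test), all three values are limits of the assay, not numbers:

- Compound 1 `COc1ccc(C(=O)N2N=C(c3ccccc3)CC2c2cn(C)c3ccccc23)cn1`: > 300000 nM (limit)
- Compound 2 `Cn1cc(C2CC(c3ccccc3)=NN2C(=O)c2cccnc2)c2cc(Br)ccc21`: > 300000 nM (limit)
- Compound 3 `COc1ccc2c(c1)c(C1CC(c3ccccc3)=NN1C(=O)c1cccnc1)cn2C`: > 300000 nM (limit)

Compound 3 sits with the others at the limit of > 300000 nM in this assay, at which 3 of the 3 values shown sit. Compound 4 `COc1ccc2c(c1)c(C1CC(c3ccccc3)=NN1C(=O)c1ccc(OC)nc1)cn2C` follows from compound 3 by one change, (methoxy in place of hydrogen on an aromatic carbon), turning pyridin-3-yl into 6-methoxypyridin-3-yl. For the measured compounds named here, the one measured step is a step that the two limits leave unreadable from compound 2 to compound 3, so it offers no size to carry over. Compound 1 already bears the 6-methoxypyridin-3-yl group, and its value of > 300000 nM is a limit. No step beyond the scatter is expected in this assay, and no direction can be given. The expected step is a number no higher from compound 3 to compound 4 (the limit leaves the size open). For compound 4 the estimate is 300000 nM, with an expected range of 150000 nM to 600000 nM.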

Compound 4, half-maximal cytotoxic concentration: > 300000 nM
Compound 4: no number, only a limit (the forecaster's own chance of this, stated with the estimate: 88%); the middle value lies on the limit itself.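

No step can be read from compound 3 to compound 4 or from compound 1 to compound 4, as each value is a limit: the limit of > 300000 nM in this assay, at which 4 of the 4 values shown sit. The compounds shown leave open how far any half-maximal cytotoxic concentration lies past that limit, and whether the methoxy group changes it.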